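A tert-butyl in place of 4-fluorophenyl on the carbonyl

This account rests on a few compounds, and the source may have more. Where it says the series, first, only, none or still open, it means among the compounds named here.

Of the compounds shown here, three sharing one core have been measured in an assay on membranes from Cortex for displacement of a labelled ligand from Sigma non-opioid intracellular receptor 1 (Cavia porcellus), read by scintillation counting, with a stated time of 120 min; a higher number here means a weaker inhibitor, a lower number a stronger inhibitor. Compound 1 `Fc1ccc(CN2CCC(NCCSC(c3ccc(F)cc3)c3ccc(F)cc3)CC2)cc1` gives 13.3 nM. Compound 2 `O=C(c1ccccc1)N1CCC(NCCSC(c2ccc(F)cc2)c2ccc(F)cc2)CC1` gives 2.03 nM. Compound 3 `O=C(c1ccc(F)cc1)N1CCC(NCCSC(c2ccc(F)cc2)c2ccc(F)cc2)CC1` gives 32.1 nM, the highest number of the three; the two measured steps leading to it read a 2.4-fold higher number from compound 1 to compound 3 (0.38 log units; beyond the scatter) and a 16-fold higher number from compound 2 to compound 3 (1.20 log units; beyond the scatter).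

Compound 4 `CC(C)(C)C(=O)N1CCC(NCCSC(c2ccc(F)cc2)c2ccc(F)cc2)CC1` has not yet been measured. It differs from compound 3 in one place: tert-butyl in place of 4-fluorophenyl on a carbonyl carbon. Among the measured compounds shown here, no measured step swaps an aromatic group for an aliphatic one on that carbonyl carbon, so the precedent is indirect. What the data do show is that the group leaving in compound 4 is the one whose fluorine cost the most, as the step of a 16-fold higher number from compound 2 to compound 3 (1.20 log units; beyond the scatter) makes plain, and that compound 3 also trails compound 1 by a 2.4-fold higher number from compound 1 to compound 3 (0.38 log units; beyond the scatter). Removing the 4-fluorophenyl altogether therefore points towards a lower number for compound 4, though without a measured aliphatic amide the size is uncertain and a return to the level of compound 2 cannot be assumed. Compound 4 is expected to give about 10 nM, within 2.5 nM to 45 nM, an expected step of a 3.2-fold lower number from compound 3 to compound 4 (0.51 log units; beyond the scatter).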

Compound 4, inhibition constant: 163 nM
For compound 4 the middle estimate is 16-fold (1.21 log units) below the measured one, and the stated range ends below it.
By their numbers in this assay, from the lowest: compound 2; then compound 1; then compound 3; then compound 4.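

In this assay compound 4 has the highest number of the four, and the step of a 5.1-fold higher number from compound 3 to compound 4 (0.71 log units; beyond the scatter) shows that on this carbonyl carbon even 4-fluorophenyl, the poorer of the two aromatic groups measured there, holds up better than tert-butyl. The gap grows to an 80-fold higher number from compound 2 to compound 4 (1.90 log units; beyond the scatter) so the group on this carbonyl carbon alone spans the whole range of numbers seen among these compounds, with phenyl at the low end and tert-butyl at the high end. The comparison with the benzylated amine, a 12-fold higher number from compound 1 to compound 4 (1.09 log units; beyond the scatter) adds that a carbonyl on the ring nitrogen does not by itself set the result, since compound 2 has a lower number than compound 1 while compound 3 and compound 4 have higher ones.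

Where a cyclohexyl or a methyl on the same carbonyl carbon would fall remains open, and so does whether the loss comes from leaving the aromatic ring or from tert-butyl in particular. Nothing available here accounts for why these groups differ as they do.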